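A few compounds are considered here, and "the series" means these few. Any claim that something is new, unique, unknown or untested is made for them only; others in the source may bear on it.

Measured in a functional assay on PC-3 cells (Homo sapiens) for inhibition, read by MTT assay, with stated times of 18 h and 4 h; a higher number here means a weaker inhibitor, a lower number a stronger inhibitor:
- compound 1 `CCCCCCCCCCOP(=O)(O)OCCSC(=S)N1CCN(C)CC1`: 80000 nM
- compound 2 `CCCCCCOP(=O)(O)OCCSC(=S)N1CCN(C)CC1`: > 100000 nM (a limit)

For compound 2, the reading of > 100000 nM is a limit of this assay and not a number. Compound 3 `CCCOP(=O)(O)OCCSC(=S)N1CCN(C)CC1` differs from compound 2 by one change: hydrogen in place of propyl on a saturated chain carbon, three bonds along the chain from an oxygen on an unsaturated carbon. For the measured compounds named here, one measured step bears on this, the same kind of replacement made further out on the chain: an at least 1.2-fold higher number from compound 1 to compound 2 (0.09 log units; that floor lies within the scatter). That step gives no sign of a stronger inhibitor, so no gain is expected here, and any change should run towards a higher number or stay within the scatter. The expected step is a step that the limit leaves unreadable from compound 2 to compound 3. For compound 3 the estimate is 150000 nM, with an expected range of 90000 nM to 300000 nM.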

Compound 3, half-maximal inhibitory concentration: > 100000 nM
Compound 3 gave a limit, no number; the forecaster's own chance of this, stated with the estimate: 85%; the middle value is on the limit's open side.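

In this assay compound 3 gives > 100000 nM, a limit of the assay and not a number. For the compounds shown here, the only step here that can be read is an at least 1.2-fold higher number from compound 1 to compound 3 (0.09 log units; that floor lies within the scatter), so hydrogen in place of heptyl at this position shows no sign of a stronger inhibitor. The step between compound 2 and compound 3 cannot be read, so nothing separates the propyl and hexyl chains, because both compounds rest at the same limit: the limit of > 100000 nM in this assay, at which 2 of the 3 values shown sit.

Going by these compounds alone, whether a longer chain would give a lower number than the one compound 1 holds stays open. Also open, going by these compounds, is what an amine or a carboxylic acid in place of propyl, at this same position on the shared core, would give.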